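The source may hold more compounds than are shown below. What is called first, only, known or untested is meant among the compounds shown, and "the series" means these compounds.

Measured so far: compound 1 `COc1cc2c(cc1OC)C(CC(N)=O)CC2` gives 26.7% in a functional assay on the whole organism (strain Wistar) for inhibition, with Rattus norvegicus as the target, read by paw edema, with stated times of 60 min and 24 h, at a dose of 100 mg/kg by the oral route; a lower number here means less inhibition, a higher number more inhibition at the dose given (going by the name of the read-out); compound 2 `COc1cc2c(cc1OC)C(CC(=O)NC1CCCC1)CC2` gives 46.7%.

Compound 2 stands highest of these two numbers; the nearest is compound 1, and the step of a number 20 percentage points higher from compound 1 to compound 2 (beyond the scatter) lies beyond the scatter. Compound 3 `COc1cc2c(cc1OC)C(CC(=O)NCCO)CC2` is not yet measured. It differs from compound 2 by 2-hydroxyethyl in place of cyclopentyl on an amide-type nitrogen. Among the measured compounds shown here, only the step from compound 1 to compound 2 bears on this change; it shows that a cyclopentyl on this nitrogen raises the number. Since the cyclopentyl now leaves again and a 2-hydroxyethyl enters, a moderate fall is expected, a number 12.7 percentage points lower from compound 2 to compound 3 (beyond the scatter). Compound 3 is estimated at 34%, between 18% and 50%.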

Compound 3, a percentage reported as inhibition, in the whole organism at one dose (the size of the read-out at that dose, not a potency): 13.3%
Compound 3: the middle estimate sits 20.7 percentage points above what was measured; measured number outside the range, below it.
By their numbers in this assay, from the lowest: compound 3; then compound 1; then compound 2.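

In this assay the amide-type nitrogen proves able to move the number in both directions. The change to 2-hydroxyethyl in place of cyclopentyl gives a number 33.4 percentage points lower from compound 2 to compound 3 (beyond the scatter) and the change to 2-hydroxyethyl in place of the amide hydrogen gives a number 13.4 percentage points lower from compound 1 to compound 3 (beyond the scatter) so a substituent on this nitrogen does not by itself raise the number. Nothing at hand explains why the two groups part ways.

The compounds shown leave open whether the carbon ring of cyclopentyl or the hydroxyl of 2-hydroxyethyl carries the difference, since the two groups differ in both. A plain ethyl or a cyclohexyl on this nitrogen would bear on that question.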